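The source may hold more compounds than are shown below. What is called first, only, known or untested is meant among the compounds shown, and "the series" means these compounds.

In a functional assay on HCT-116 cells (Homo sapiens) for cytotoxicity, read by MTT assay, with a stated time of 72 h (on this read-out higher numbers stand for weaker inhibition and lower numbers for stronger inhibition), compound 3 `Cc1cc(/C=C/c2ccc(O)cc2)on1` gives 67900 nM. Compound 1 `COc1ccc(/C=C/c2cc(C)no2)cc1OC` gives 87400 nM, and these two values lie within the usual scatter of each other. Compound 2 `Cc1cc(/C=C/c2ccc(O)c(O)c2)on1` stands well apart at 5300 nM.

The next compound, compound 4 `COc1cc(/C=C/c2cc(C)no2)ccc1O`, differs from compound 3 by one change: methoxy in place of hydrogen on an aromatic carbon. This places methoxy in place of hydrogen on an aromatic carbon, ortho to a hydroxy group.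

Within the data shown here, the only measured step at that carbon is a 13-fold higher number from compound 2 to compound 3 (1.11 log units; beyond the scatter), a large step that removes a hydroxy rather than adding a methoxy. It suggests that a group at this carbon can matter. However, compound 1, which also carries methoxy there but has no hydroxy, gives 87400 nM, so methoxy may not bring the gain seen with hydroxy. A small move toward a lower number is therefore expected, and the expected step is a 1.7-fold lower number from compound 3 to compound 4 (0.23 log units; within the scatter). The estimate for compound 4 is 40000 nM, with an expected range from 14000 nM to 95000 nM.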

Compound 4, half-maximal inhibitory concentration: 33400 nM
Estimate against measurement, compound 4: 1.2-fold (0.08 log units) above, and the stated range covers the measured number.
By their numbers in this assay, from the lowest: compound 2; then compound 4; then compounds 3 and 1 (each within the scatter of the next).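

In this assay, methoxy at this carbon, ortho to a hydroxy group, does shift the number, though only modestly (a 2.0-fold lower number from compound 3 to compound 4 (0.31 log units; beyond the scatter)), and this step lies beyond the scatter. The same carbon with a free hydroxy gives a lower number still, and capping that oxygen with methyl reverses part of the gain (a 6.3-fold higher number from compound 2 to compound 4 (0.80 log units; beyond the scatter)), so at this carbon hydroxy and methoxy are not equivalent. The other oxygen matters too: with methoxy held at this carbon, a free hydroxy in place of a second methoxy also gives a lower number (a 2.6-fold lower number from compound 1 to compound 4 (0.42 log units; beyond the scatter)).

Nothing measured here explains why these steps arise. Going by these compounds, whether an amine or a longer chain such as ethoxy at this carbon would follow hydroxy, methoxy or neither remains open.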